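The source may report more compounds than this note shows. Statements on the series, on what has been measured and on what is new or still open speak of the compounds shown alone.

In an ADME assay on the whole organism (Mus musculus, strain CD-1) for pharmacokinetics, at a dose of 10 mg/kg by the oral route (a higher number here means more compound in the circulation at the dose given, a lower number less compound in the circulation), three compounds have been measured so far. Compound 1 (`COc1cc([C@](O)(CCN(C)C)[C@@H](c2cc3cc(Br)ccc3nc2OC)c2cccc(OC)c2F)cc(SC)n1`) gives 4600 ng.h/mL, compound 2 (`COc1cc([C@](O)(CCN(C)C)[C@@H](c2cc3cc(C#N)ccc3nc2OC)c2cccc(OC)c2F)cc(SC)n1`) gives 1100 ng.h/mL and compound 3 (`CCOc1cc([C@](O)(CCN(C)C)[C@@H](c2cc3cc(Br)ccc3nc2OC)c2ccnc(OC)c2OC)cc(OC(C)C)n1`) gives 32000 ng.h/mL, which leaves compound 2 the lowest of the three. Compound 4 (`COc1cccc([C@H](c2cc3cc(C#N)ccc3nc2OC)[C@@](O)(CCN(C)C)c2cc(SC)nc(SC)c2)c1F`) differs from compound 2 by methylsulfanyl in place of methoxy on an aromatic carbon, next to the ring nitrogen: methylsulfanyl in place of methoxy on an aromatic carbon. Within the data shown here, no measured pair contains this swap. Among the measured compounds shown here, the only measured single change is cyano in place of bromo, a 4.2-fold lower number from compound 1 to compound 2 (0.62 log units; beyond the scatter), and it sits elsewhere on the molecule. It shows that one replacement can move this number beyond the scatter, but it gives no direction for the present swap. Compound 3 differs from compound 2 in several places, so its value cannot be tied to any one of them. With no direct evidence, the expected change is none beyond the scatter, and the step expected is a 1.2-fold higher number from compound 2 to compound 4 (0.07 log units; within the scatter). For compound 4 the estimated value is 1300 ng.h/mL, with an expected range from 450 ng.h/mL to 3800 ng.h/mL.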

Compound 4, area under the concentration-time curve: 1100 ng.h/mL
Estimate against measurement, compound 4: 1.2-fold (0.07 log units) above; measured number inside the range.
By their numbers in this assay, from the lowest: compounds 2 and 4 (each within the scatter of the next); then compound 1; then compound 3.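

Putting methylsulfanyl in place of methoxy on this aromatic carbon, next to the ring nitrogen, gives no change at the digits printed from compound 2 to compound 4 (within the scatter) in this assay, so on the core of compound 2 this position accepts the swap with no shift that can be told from the scatter. Among these compounds, the one single change available before, cyano in place of bromo (a 4.2-fold lower number from compound 1 to compound 2 (0.62 log units; beyond the scatter)), lay elsewhere on the molecule and said nothing about this position; now there is also a replacement that leaves the number where it was. Nothing measured here explains why the two groups read alike.

From the compounds shown here alone, whether the number would hold with a quite different group at this position, such as a carboxylic acid or a longer chain like butoxy, remains open. So does whether the same swap would read alike with bromo in place of cyano, as in compound 1.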